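This account rests on a few compounds, and the source may have more. Where it says the series, first, only, none or still open, it means among the compounds named here.

In a functional assay on HEK293 cells for positive allosteric modulation of metabotropic glutamate receptor 5 (Rattus norvegicus), read by fluorescence and calcium flux (on this read-out higher numbers stand for larger maximal responses and lower numbers for smaller maximal responses), three compounds have been measured so far:

Compound 1 `C[C@@H](NC(=O)c1ccc(C#Cc2ccc(F)cc2)cn1)C(C)(C)O` gives 66.2%.
Compound 2 `C[C@@H](NC(=O)c1ccc(C#Cc2cc(F)cc(F)c2)cn1)C(C)(C)O` gives 61.6%.
Compound 3 `Cc1ccccc1C#Cc1ccc(C(=O)N[C@H](C)C(C)(C)O)nc1` gives 59.9%.

Compound 3 has the smallest of the three numbers, but the distances are small: the step of a number 1.7 percentage points lower from compound 2 to compound 3 (within the scatter) and the step of a number 6.3 percentage points lower from compound 1 to compound 3 (within the scatter) both lie within the scatter of repeated measurements, so the three compounds cannot be told apart on this read-out.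

Compound 4 `C[C@@H](NC(=O)c1ccc(C#Cc2cccnc2)cn1)C(C)(C)O` is the next compound to be measured. It differs from compound 3 in one place: pyridin-3-yl in place of 2-methylphenyl on a triple-bonded carbon. All three compounds share the same core, and in every measured step only the aromatic group on the triple-bonded carbon was exchanged. Those exchanges, a number 4.6 percentage points lower from compound 1 to compound 2 (within the scatter), a number 6.3 percentage points lower from compound 1 to compound 3 (within the scatter) and a number 1.7 percentage points lower from compound 2 to compound 3 (within the scatter), all stayed within the scatter. The change to compound 4 is an exchange of the same kind, so in this assay no step beyond the scatter is expected from it. The step of a number 0.1 percentage points higher from compound 3 to compound 4 (within the scatter) is the estimated outcome. Compound 4 is therefore expected to reach about 60%, with a likely range from 48% to 72%.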

Compound 4, largest response reached (reported as efficacy), in percent of the reference or control that the assay uses: 71.5%
Beside the measured number, compound 4's estimate is 11.5 percentage points below it, within the range that was stated.
By their numbers in this assay, from the lowest: compounds 3, 2, 1 and 4 (each within the scatter of the next, the first and the last beyond it).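

In this assay, for the compounds shown here, pyridin-3-yl in place of 2-methylphenyl on a triple-bonded carbon gives a number 11.6 percentage points higher from compound 3 to compound 4 (beyond the scatter) and is the first step at this position to lie beyond the scatter, so the group held here can shift the maximal response by more than repeat measurements would. The shift is limited, though: pyridin-3-yl in place of 3,5-difluorophenyl gives a number 9.9 percentage points higher from compound 2 to compound 4 (within the scatter) and pyridin-3-yl in place of 4-fluorophenyl gives a number 5.3 percentage points higher from compound 1 to compound 4 (within the scatter) and neither step separates the two compounds involved, so compound 4 stands clear of compound 3 alone. Pyridin-3-yl is the only group of the four with a ring nitrogen, yet no measurement here accounts for the step.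

As far as these compounds go, how plain phenyl, pyridin-2-yl or pyridin-4-yl would behave on the triple-bonded carbon remains open, and with it the question of whether the ring nitrogen and its place in the ring matter at all. From the compounds shown here alone, it is also open whether a larger group, such as a naphthyl ring, or a saturated one, such as cyclohexyl, would keep the maximal response in this range.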